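The compounds below may be only part of what the source reports. "The series", "measured", "known", "first", "only" and "open" are said of these compounds alone.

In an assay on HEK293 cells for antagonist activity at Toll-like receptor 9 (Homo sapiens), read by spectrophotometry (on this read-out lower numbers stand for stronger inhibition and higher numbers for weaker inhibition), compound 1 `CCN1CCN(CCCn2cnc3c(N4CCN(C5CCCC5)CC4)nc(N)nc32)CC1` gives 280 nM. Compound 2 `CCN1CCN(CCCn2cnc3c(N4CCN(C(=O)C5CCCC5)CC4)nc(NCc4ccc(OC)cc4)nc32)CC1` is reported in this assay only as a limit of the assay, namely > 30000 nM. On the numbers shown, compound 2 therefore stands at the weak end, since the limit of > 30000 nM in this assay, at which 1 of the 2 values shown sits, describes where its value sits. Compound 3 `CCN1CCN(CCCn2cnc3c(N4CCN(C5CCCC5)CC4)nc(NCc4ccc(OC)cc4)nc32)CC1` has not yet been measured in this assay. It differs from compound 2 in a single place: cyclopentyl in place of cyclopentylcarbonyl on an amine nitrogen in a ring. Going by the values given here, no measured pair differs by exactly this change, so the size of the step cannot be read from the data; the author expects a step towards stronger inhibition, well beyond the usual scatter. Compound 3 is estimated to give 3000 nM in this assay, within a range of 300 nM to 30000 nM. The estimated step of an at least 10-fold lower number from compound 2 to compound 3 (1.00 log units; beyond the scatter) is what that number would mean.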

Compound 3, half-maximal inhibitory concentration: 120 nM
Estimate against measurement, compound 3: 25-fold (1.40 log units) above; measured number below the stated range.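

In this assay, replacing cyclopentylcarbonyl with cyclopentyl on the amine nitrogen in a ring gives an at least 250-fold lower number from compound 2 to compound 3 (2.39 log units; beyond the scatter), the first measured sign that this single change can matter greatly at this position, at least with 4-methoxybenzyl present. Compound 2 stands only at a limit of the assay: the limit of > 30000 nM in this assay, at which 1 of the 3 values shown sits. With cyclopentyl held in place, the other single change, on a nitrogen on an aromatic ring, gives a 2.3-fold lower number from compound 1 to compound 3 (0.37 log units; beyond the scatter), so 4-methoxybenzyl in place of hydrogen costs no inhibition and brings a modest gain.

The compounds shown leave open whether an acetyl or a benzyl group on the same amine nitrogen in a ring would read like cyclopentyl or like cyclopentylcarbonyl. They also leave open whether cyclopentylcarbonyl has the same effect with hydrogen in place of 4-methoxybenzyl, and how an unsubstituted benzyl would read on the nitrogen on an aromatic ring.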